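Swapping a Dichlorophenyl for a Methoxyphenyl

This account rests on a few compounds, and the source may have more. Where it says the series, first, only, none or still open, it means among the compounds named here.

Measured compounds:
- compound 1, `COc1ccccc1/C=c1/[nH]c(=O)/c(=C\c2ccccc2OC)n(C)c1=O`: 7000 nM
- compound 2, `C=CCn1c(=O)/c(=C\c2ccccc2Cl)[nH]c(=O)/c1=C\c1ccccc1OC`: 5300 nM
- compound 3, `C=CCn1c(=O)/c(=C\c2ccc(Cl)c(Cl)c2)[nH]c(=O)/c1=C\c1ccccc1OC`: no number reported

Of the compounds shown here, three built on one shared core have been tested in a functional assay on A549 cells (Homo sapiens) for cytotoxicity, read by CCK-8 assay, with a stated time of 72 h; on this read-out lower numbers stand for stronger inhibition and higher numbers for weaker inhibition. Compound 1 gives 7000 nM in this assay. Compound 2 gives 5300 nM in this assay; the two values are within the scatter of each other, so neither can be called the stronger. Compound 3 stands apart: in this assay compound 3 was reported as "not active" (no number reported), with no number at all, so it has no place on the numerical scale that compound 1 and compound 2 occupy.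

The step to compound 4, `C=CCn1c(=O)/c(=C\c2ccccc2OC)[nH]c(=O)/c1=C\c1ccccc1OC`, is a single change: 2-methoxyphenyl in place of 3,4-dichlorophenyl on a double-bonded chain carbon bound to an aromatic carbon. What results is a molecule carrying two 2-methoxyphenyl groups, which makes compound 4 a close relative of compound 1 and of compound 2, both of which carry at least one 2-methoxyphenyl group and both of which do give a number in this assay. Because compound 1 gives 7000 nM and compound 2 gives 5300 nM, while compound 3 gives "not active" (no number reported), the expectation is a move back into the measurable range, with a value of the same general size as those two, the direction being toward stronger inhibition, though the size of that move cannot be put as a number since compound 3 has none. For compound 4, the estimated value in this assay is 6000 nM, with a likely range from 2500 nM to 15000 nM.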

Compound 4, half-maximal inhibitory concentration: 22400 nM
Compound 4: middle estimate off by 3.7-fold (0.57 log units), on the low side; the whole stated range lies below it.
By their numbers in this assay, from the lowest: compounds 2 and 1 (each within the scatter of the next); then compound 4.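

In this assay compound 4 gives a real number (22400 nM) where compound 3 was reported as not active, which shows that 2-methoxyphenyl in place of 3,4-dichlorophenyl on a double-bonded chain carbon bound to an aromatic carbon restores a measurable effect, although compound 3 has no number from which to size that change. The recovery is only partial: methoxy in place of chloro on an aromatic carbon gives a 4.2-fold higher number from compound 2 to compound 4 (0.63 log units; beyond the scatter) in a modest step beyond the scatter, so at this place the 2-methoxyphenyl group reads weaker than the chlorine-bearing ring of compound 2. The other end of the molecule also matters, since vinyl in place of hydrogen on a saturated chain carbon bound to an aromatic nitrogen gives a 3.2-fold higher number from compound 1 to compound 4 (0.51 log units; beyond the scatter) as a second modest step beyond the scatter.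

Still open, as far as these compounds go, is how an amine, a carboxylic acid or a fluorine on that aromatic ring would read in this assay, and whether a longer chain on the aromatic nitrogen would continue the same trend. Nothing available here explains why either step goes the way it does.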